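Adding a chloro group to a compound tolerated at the assay limit

The source may hold more compounds than are shown below. What is called first, only, known or untested is meant among the compounds shown, and "the series" means these compounds.

Compound 3 `COC(=O)CNC(=O)c1c(NO)cc(-c2ccccc2)oc1=O` gives in an ADME assay on Huh-7 cells (Homo sapiens) for cytotoxicity, read by a luciferase reporter and WST assay, with a stated time of 3 days (a lower number here means that less compound is tolerated, a higher number that more compound is tolerated), only a limit, > 20000 nM, so its true number is not known. Going by the values given here, this is common among the three compounds measured so far: the limit of > 20000 nM in this assay, at which 2 of the 3 values shown sit. Compound 1 `O=C(Nc1ccccc1)c1c(NO)cc(-c2ccc(Cl)cc2)oc1=O` gives 11000 nM. Compound 2 `CNC(=O)c1c(NO)cc(-c2ccc(Cl)cc2)oc1=O` gives a limit, > 20000 nM. Among the compounds with values here, the single one-place step is an at least 1.8-fold higher number from compound 1 to compound 2 (0.25 log units; that floor lies within the scatter), a change on the amide-type nitrogen that does not touch the aromatic ring. Within the data shown here, compound 4 `COC(=O)CNC(=O)c1c(NO)cc(-c2ccc(Cl)cc2)oc1=O` differs from compound 3 by chloro in place of hydrogen on an aromatic carbon, a change no measured step covers. Compound 1 carries the same 4-chlorophenyl group and sits at a number rather than a limit, but it also differs at the amide, so nothing fixes the size of this step. Compound 4 is therefore expected to be tolerated much as compound 3, giving an estimated step of an at least 1.1-fold lower number from compound 3 to compound 4 (0.04 log units; that floor lies within the scatter). The estimate for compound 4 is 18000 nM, between 8000 nM and 40000 nM.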

Compound 4, half-maximal cytotoxic concentration: > 20000 nM
Compound 4: a limit, no number; the forecaster's own chance of this, stated with the estimate: 55%; middle value at least 1.1-fold (0.04 log units) away from the limit.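

Compound 4 gives only a limit in this assay. Chloro in place of hydrogen on the aromatic ring therefore yields no number here, and the steps to compound 4 from compound 3 and from compound 2 cannot be read. The only readable step is an at least 1.8-fold higher number from compound 1 to compound 4 (0.25 log units; that floor lies within the scatter), a change on the amide-type nitrogen, and limits now make up most of the series: the limit of > 20000 nM in this assay, at which 3 of the 4 values shown sit.

Going by these compounds alone, no pair with a number on both sides isolates the phenyl to 4-chlorophenyl change. Also open, as far as these compounds go, is how an amine or a carboxylic acid in place of the methoxycarbonyl group would stand.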